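The source may report more compounds than this note shows. Statements on the series, on what has been measured and on what is new or still open speak of the compounds shown alone.

Measured in a functional assay with Rattus norvegicus as the target; on this read-out higher numbers stand for weaker inhibition and lower numbers for stronger inhibition:

Compound 1, `COc1cccc2[nH]c(=O)c(=O)oc12`, gives 7000 nM.
Compound 2, `COc1ccc2[nH]c(=O)c(=O)oc2c1`, gives 28000 nM.
Compound 3, `O=c1[nH]c2cc(C(F)(F)F)ccc2oc1=O`, gives 100000 nM.

Among these three numbers compound 2 stands second highest. Its nearest neighbour is compound 3, whose number is higher by a margin beyond the usual scatter, and its furthest neighbour is compound 1, whose number is lower, again by a margin beyond the scatter. Among the measured compounds shown here, the three compounds differ from one another in more than one place, so no single structural step between them can be isolated.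

Compound 4, `Cc1ccc2[nH]c(=O)c(=O)oc2c1`, has not yet been measured. It differs from compound 2 by methyl in place of methoxy on an aromatic carbon. The methoxy leaves and a methyl enters on an aromatic carbon of a six-membered aromatic ring of carbon only, part of a fused system of two rings. For the measured compounds named here, no measured pair shows what this exchange does on the shared core, so the expectation rests on compound 2 alone. A step no larger than the scatter is expected in this assay, with no clear direction. Compound 4 is therefore estimated at 30000 nM, within a range from 10000 nM to 90000 nM, which means an expected step of a 1.1-fold higher number from compound 2 to compound 4 (0.03 log units; within the scatter).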

Compound 4, half-maximal inhibitory concentration: 32000 nM
Compound 4: middle estimate off by 1.1-fold (0.03 log units), on the low side, within the range that was stated.
By their numbers in this assay, from the lowest: compound 1; then compounds 2 and 4 (each within the scatter of the next); then compound 3.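

In this assay, methyl in place of methoxy on this aromatic carbon, meta to a fused ring and para to a fused ring, gives a 1.1-fold higher number from compound 2 to compound 4 (0.06 log units; within the scatter). Among the compounds shown here, this is the first pair here that differs in one place, and it shows that losing one heavy atom and the group's single hydrogen-bond acceptor leaves the two compounds indistinguishable in this read-out, since the step lies within the scatter. No separate measurement is available to explain this result.

As far as these compounds go, whether an amine, a carboxylic acid or a longer chain such as butyl on the same carbon would move the number beyond the scatter remains open. So does whether methyl in place of methoxy would give a similarly small step on another carbon of the ring.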